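Removing the indole methyl of compound 2

The compounds below may be only part of what the source reports. "The series", "measured", "known", "first", "only" and "open" are said of these compounds alone.

Of the compounds shown here, three on a shared core have been measured in a toxicity assay (Homo sapiens) for cytotoxicity, read by MTT assay, with a stated time of 48 h; a higher number here means a weaker inhibitor, a lower number a stronger inhibitor. Compound 2 `Cc1[nH]c2ccccc2c1C(C1=C(O)C(=O)c2ccccc2C1=O)c1ccc(Cl)cc1` gives 40300 nM, the highest of the three numbers. Compound 1 `O=C1C(O)=C(C(c2ccccc2)c2c(-c3ccccc3)[nH]c3ccccc23)C(=O)c2ccccc21` gives 26400 nM in this assay, within the scatter of compound 2; compound 1 differs from compound 2 in more than one place, so only the two values are set side by side. Among the measured compounds shown here, compound 3 `Cc1[nH]c2ccccc2c1C(C1=C(O)C(=O)c2ccccc2C1=O)c1ccc([N+](=O)[O-])cc1` gives 15100 nM, and the step of a 2.7-fold lower number from compound 2 to compound 3 (0.43 log units; beyond the scatter) is the only single-point step in the set.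

Compound 4 `O=C1C(O)=C(C(c2ccc(Cl)cc2)c2c[nH]c3ccccc23)C(=O)c2ccccc21` differs from compound 2 as follows: hydrogen in place of methyl on an aromatic carbon. For the measured compounds named here, no measured step alters this part of the core; the one measured step, nitro for chloro, lies on a different ring. There is thus no basis for expecting a step in this assay beyond the scatter in either direction for compound 4. Compound 4 is accordingly estimated at 35000 nM in this assay, with a range from 15000 nM to 80000 nM. The expected step of a 1.2-fold lower number from compound 2 to compound 4 (0.06 log units; within the scatter) is taken as none beyond the scatter.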

Compound 4, half-maximal inhibitory concentration: 102000 nM
Estimate against measurement, compound 4: 2.9-fold (0.46 log units) below; the whole stated range lies below it.
By their numbers in this assay, from the lowest: compounds 3, 1 and 2 (each within the scatter of the next, the first and the last beyond it); then compound 4.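

Position note: in this assay, the aromatic carbon of the five-membered ring, next to the ring nitrogen, proves responsive to substitution, since hydrogen in place of methyl gives a 2.5-fold higher number from compound 2 to compound 4 (0.40 log units; beyond the scatter). Among the compounds shown here, the earlier single-point step, a 2.7-fold lower number from compound 2 to compound 3 (0.43 log units; beyond the scatter), lay on a different ring, so this is the first reading at this carbon. Loss of one heavy atom is enough to move the number beyond the scatter, and retaining the methyl gives the lower number of this pair. Nothing available bears on the origin of this step.

Open: whether an ethyl group, a longer chain or an amine at this carbon would lower the number further than methyl. Also open, on these data alone, is whether nitro in place of chloro acts the same way on compound 4 as on compound 2.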